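Replacing 2-methylphenyl on the sulfonamide of compound 3

A few compounds are considered here, and "the series" means these few. Any claim that something is new, unique, unknown or untested is made for them only; others in the source may bear on it.

Compound 1 `O=C(/C=C/c1cccnc1)NCCCCc1ccc(S(=O)(=O)Nc2ccccc2)cc1` gives 5.03 nM
Compound 2 `O=C(/C=C/c1cccnc1)NCCCCCc1ccc(S(=O)(=O)Nc2ccccc2)cc1` gives 95.7 nM
Compound 3 `Cc1ccccc1NS(=O)(=O)c1cccc(CCCCCCNC(=O)/C=C/c2cccnc2)c1` gives 0.226 nM

All three values come from a functional assay on MCF7 cells (Homo sapiens) for inhibition, read by CCK-8 assay, with a stated time of 72 h (on this read-out higher numbers stand for weaker inhibition and lower numbers for stronger inhibition), and compound 3 (0.226 nM) has the lowest number, with compound 1 and compound 2 higher beyond the scatter. Compound 4 (`O=C(/C=C/c1cccnc1)NCCCCCCc1cccc(S(=O)(=O)Nc2ccc(C(F)(F)F)cc2)c1`) awaits measurement. It carries 4-(trifluoromethyl)phenyl in place of 2-methylphenyl on a sulfonamide nitrogen. Going by the values given here, no measured pair isolates this change, so the expectation is loose. Among the compounds with values here, compound 3 (0.226 nM) sits at the bottom of the numbers so far, so a rise looks likelier than a further drop. The expected move toward weaker inhibition, beyond the scatter, is (a 6.6-fold higher number from compound 3 to compound 4 (0.82 log units; beyond the scatter)). For compound 4 the estimate is 1.5 nM, with an expected range of 0.15 nM to 15 nM.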

Compound 4, half-maximal inhibitory concentration: 67.8 nM
For compound 4 the middle estimate is 45-fold (1.66 log units) below the measured one, and the stated range ends below it.
By their numbers in this assay, from the lowest: compound 3; then compound 1; then compounds 4 and 2 (each within the scatter of the next).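

In this assay, 4-(trifluoromethyl)phenyl in place of 2-methylphenyl on the sulfonamide nitrogen gives a 300-fold higher number from compound 3 to compound 4 (2.48 log units; beyond the scatter). This is the only single-place change shown, and it marks the group on this nitrogen as a strong determinant of the read-out, with the rest of the structure held constant. Nothing on hand accounts for the size of this step. Still open, going by these compounds, is whether the loss follows the departure of 2-methylphenyl or the arrival of 4-(trifluoromethyl)phenyl. On these data alone, how a methoxyphenyl or pyridyl group on this nitrogen would read on the same core also remains open.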